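The source may report more compounds than this note shows. Statements on the series, on what has been measured and on what is new or still open speak of the compounds shown alone.

For the measured compounds named here, compound 1 `COc1ccccc1N1CCN(CCn2c(=O)[nH]c3cc[nH]c3c2=O)CC1` is one of three compounds measured in an assay for binding affinity to Adrenergic receptor alpha-1 (Rattus norvegicus) (a lower number here means a stronger inhibitor, a higher number a weaker inhibitor), where compound 1 gives 2.31 nM. Compound 2 `O=c1[nH]c2cc[nH]c2c(=O)n1CCN1CCN(c2ccccc2Cl)CC1` gives 0.94 nM in this assay, and compound 3 `O=c1[nH]c2cc(-c3ccccc3)[nH]c2c(=O)n1CCCN1CCN(c2ccccc2Cl)CC1` gives 62.4 nM. Compound 1 therefore stands second highest of the three numbers, between compound 2 and compound 3.

Compound 4 `COc1ccccc1N1CCN(CCn2c(=O)[nH]c3cc(-c4ccccc4Cl)[nH]c3c2=O)CC1` is not yet measured. It differs from compound 1 in one place: 2-chlorophenyl in place of hydrogen on an aromatic carbon. Going by the values given here, the only step recorded between measured compounds, a 2.5-fold lower number from compound 1 to compound 2 (0.39 log units; beyond the scatter), concerns the other end of the molecule and does not speak to this change. What does bear on it is the comparison of compound 2 and compound 3: compound 3 carries an aromatic ring at the same position on the shared core, along with a longer chain, and its value in this assay is far higher than that of compound 2. The aryl group on the five-membered ring thus appears to come with much weaker binding, though the chain length also changed there.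

Compound 4 is expected to bind more weakly than compound 1, with a step of a 22-fold higher number from compound 1 to compound 4 (1.34 log units; beyond the scatter), giving an estimated value of 50 nM, in a range from 8 nM to 300 nM.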

Compound 4, inhibition constant: 0.76 nM
Compound 4: middle estimate off by 66-fold (1.82 log units), on the high side; measured number below the stated range.
By their numbers in this assay, from the lowest: compounds 4 and 2 (each within the scatter of the next); then compound 1; then compound 3.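

In this assay, placing 2-chlorophenyl on the aromatic carbon next to the ring nitrogen gives a 3.0-fold lower number from compound 1 to compound 4 (0.48 log units; beyond the scatter), so this position accepts a whole aromatic ring with no loss of binding. Compound 3, at 62.4 nM, also carries an aromatic ring here, together with a longer chain, so its weak binding can no longer be read as the price of the ring alone. Nothing in the data shown explains why binding changes with this group.

The compounds shown leave open what the chlorine contributes, which a plain phenyl on the core of compound 1 would show directly. They also leave open how much else this position tolerates, such as a methyl group, an amine or a carboxylic acid.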